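The compounds below may be only part of what the source reports. "The series", "measured", "known", "first", "only" and "open" are said of these compounds alone.

Measured so far in a functional assay on HCT-116 cells (Homo sapiens) for antiproliferative activity, read by MTT assay, with a stated time of 48 h; on this read-out lower numbers stand for stronger inhibition and higher numbers for weaker inhibition
- compound 1 `COc1ccc(CN(C(=O)CSc2nc3ccccc3s2)c2cc(OC)c(OC)c(OC)c2)cc1` gives 426 nM
- compound 2 `COc1ccc(CN(C(=O)CSc2nc3ccccc3s2)c2cc(OC)c(OC)c(OC)c2)cc1F` gives 1830 nM

Not yet measured: compound 3 `COc1cc(N(Cc2ccc(Br)cc2)C(=O)CSc2nc3ccccc3s2)cc(OC)c1OC`.

Compound 2 holds the higher of the two numbers (1830 nM). Moving to compound 3 puts 4-bromophenyl in place of 3-fluoro-4-methoxyphenyl on a saturated chain carbon bound to an amide-type nitrogen. Within the data shown here, only one measured step bears on this, a modest one beyond the scatter (a 4.3-fold higher number from compound 1 to compound 2 (0.63 log units; beyond the scatter)), where fluoro replaces hydrogen on an aromatic carbon. Among the measured compounds shown here, compound 3 lacks that fluoro, but no measured compound carries bromine, so the expectation in this assay is loose. A modest move to a lower number is expected (a 2.3-fold lower number from compound 2 to compound 3 (0.36 log units; beyond the scatter)). For compound 3 the estimated value is 800 nM (expected range 250 nM to 2500 nM).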

Compound 3, half-maximal inhibitory concentration: 63800 nM
For compound 3 the middle estimate is 80-fold (1.90 log units) below the measured one, and the stated range ends below it.
By their numbers in this assay, from the lowest: compound 1; then compound 2; then compound 3.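

In this assay the substituent on the benzyl group bound to the amide-type nitrogen tolerates far less change than the fluoro step indicated. Moving from 3-fluoro-4-methoxybenzyl to 4-bromobenzyl gives a 35-fold higher number from compound 2 to compound 3 (1.54 log units; beyond the scatter) and bromo in place of methoxy gives a 150-fold higher number from compound 1 to compound 3 (2.18 log units; beyond the scatter) on the same read-out, a larger change than fluoro in place of hydrogen produced. No supporting data account for this loss. From the compounds shown here alone, whether chloro, hydroxy or an amine in place of the methoxy would stay close to compound 1 remains open, as does whether bromine or the missing methoxy drives the change.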